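A few compounds are considered here, and "the series" means these few. Any claim that something is new, unique, unknown or untested is made for them only; others in the source may bear on it.

Measured to date in an assay on isolated protein for inhibition of serine/threonine-protein kinase Chk2 (Homo sapiens), read by mobility shift assay, tested at 30 uM; on this read-out lower numbers stand for less inhibition and higher numbers for more inhibition at the one concentration tested (going by the name of the read-out):
- compound 1 `COc1ccc(-c2cc3[nH]nc(N)c3c(=O)[nH]2)cc1`; compound 1 gives 43%
- compound 2 `COCCNc1nc(C)cc2c1c(N)nn2C`; compound 2 gives -2%
- compound 3 `COCCNc1nc(-c2ccccc2)cc2c1c(N)nn2C`; compound 3 gives 8%

Compound 3 stands second highest of the three numbers: a number 10 percentage points higher from compound 2 to compound 3 (within the scatter) lies within the scatter, whereas compound 1 sits well above compound 3, beyond the scatter. Compound 4 `Cn1nc(N)c2cnc(-c3ccccc3)cc21` differs from compound 3 by hydrogen in place of (2-methoxyethyl)amino on an aromatic carbon. Within the data shown here, the only measured step, a number 10 percentage points higher from compound 2 to compound 3 (within the scatter), concerns a different aromatic carbon and does not bear on this change; no measured pair shows the (2-methoxyethyl)amino group replaced by hydrogen. With nothing to lean on, no step beyond the scatter is expected, a number 3 percentage points lower from compound 3 to compound 4 (within the scatter). Compound 4 is therefore estimated at 5%, with a range of -10% to 20%.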

Compound 4, a percentage reported as inhibition, at one concentration (the size of the read-out at that concentration, not a potency): 5%
Compound 4: middle estimate and measured number agree at the digits printed, and the stated range covers the measured number.
By their numbers in this assay, from the lowest: compounds 2, 4 and 3 (each within the scatter of the next); then compound 1.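

In this assay, hydrogen in place of (2-methoxyethyl)amino on the aromatic carbon next to the ring nitrogen gives a number 3 percentage points lower from compound 3 to compound 4 (within the scatter). With phenyl held fixed, the number in this assay therefore stays level on loss of the whole chain, without a change beyond the scatter at the one concentration tested. Nothing on hand accounts for this result. Still open, going by these compounds, is whether a carboxylic acid, a morpholine or a longer chain at this carbon would move the number beyond the scatter. Also open, on these data alone, is whether the same replacement behaves alike with methyl in place of phenyl.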